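Adding a further methyl to the methoxyphenyl compounds

The compounds below may be only part of what the source reports. "The series", "measured", "known", "first", "only" and "open" are said of these compounds alone.

Values in a functional assay on KB cells (Homo sapiens) for antiproliferative activity, read by sulforhodamine B assay, with a stated time of 3 days; on this read-out lower numbers stand for an effect already at smaller amounts and higher numbers for an effect only at larger amounts of compound:
- Compound 1 `CCC1=C(O)c2c(oc(-c3ccccc3F)cc2=O)C(CC)(CC)C1=O`: > 56.2 uM, a limit of the assay
- Compound 2 `CCC1=C(O)c2c(oc(-c3ccc(OC)cc3C)cc2=O)C(CC)(CC)C1=O`: 20.9 uM
- Compound 3 `CCC1=C(O)c2c(oc(-c3ccc(OC)c(C)c3)cc2=O)C(CC)(CC)C1=O`: 28.5 uM

Compound 3 cannot be separated from compound 2, with a 1.4-fold higher number from compound 2 to compound 3 (0.13 log units; within the scatter). Compound 4 `CCC1=C(O)c2c(oc(-c3ccc(OC)c(C)c3C)cc2=O)C(CC)(CC)C1=O` follows from compound 3 by methyl in place of hydrogen on an aromatic carbon, ortho to a large group and ortho to a methyl group. Compound 4 thus carries the methyl groups of both compound 2 and compound 3. The small step between those two is the closest guide. The steps of an at least 2.6-fold lower number from compound 1 to compound 2 (0.42 log units; beyond the scatter) and an at least 1.9-fold lower number from compound 1 to compound 3 (0.29 log units; that floor lies within the scatter) exchange far more than one methyl and bear only loosely. No change beyond the scatter is therefore expected, with an estimated 1.2-fold lower number from compound 3 to compound 4 (0.09 log units; within the scatter). For compound 4 the estimated value is 23 uM, with an expected range of 10 uM to 50 uM.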

Compound 4, concentration for half-maximal effect: 5.43 uM
Estimate against measurement, compound 4: 4.2-fold (0.63 log units) above; measured number outside the range, below it.
By their numbers in this assay, from the lowest: compound 4; then compounds 2 and 3 (each within the scatter of the next). At a limit, above all of these: compound 1.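

In this assay the methyl ortho to a large group and ortho to a methyl group gives a 5.2-fold lower number from compound 3 to compound 4 (0.72 log units; beyond the scatter) and so sets compound 4 apart from two compounds that the scatter could not separate. A further methyl on compound 2 gives a 3.8-fold lower number from compound 2 to compound 4 (0.59 log units; beyond the scatter) as well, so among the compounds shown the clearly lower number comes only with both methyl groups present. Nothing measured here accounts for this change.

As far as these compounds go, whether an ethyl group or a chlorine atom in this place would give the same result stays open. So does whether the methoxy group is needed alongside the two methyl groups.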